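The compounds below may be only part of what the source reports. "The series", "measured", "known", "first", "only" and "open" are said of these compounds alone.

The measured compounds are:
compound 1, `O=C1C(c2ccccc2)CC(c2ccccc2)C(=O)N1Cc1ccccc1`, which in a functional assay on the whole organism (strain Swiss albino) for inhibition, with Mus musculus as the target, in the maximal electroshock model, with a stated time of 2 h, at a dose of 25 mg/kg by the intraperitoneal route (on this read-out lower numbers stand for less inhibition and higher numbers for more inhibition at the one dose given (going by the name of the read-out)), gives 64.5%;
compound 2, `NN1C(=O)C(c2ccccc2)CC(c2ccccc2)C1=O`, which gives 76%;
compound 3, `O=C1C(c2ccccc2)CC(c2ccccc2)C(=O)N1c1cccc(Cl)c1`, which gives 32.2%.

Compound 3 stands lowest of the three. The nearest number is that of compound 1, and the step runs a number 32.3 percentage points lower from compound 1 to compound 3 (beyond the scatter). The furthest is that of compound 2, with a number 43.8 percentage points lower from compound 2 to compound 3 (beyond the scatter). Between the two higher compounds the change is a number 11.5 percentage points higher from compound 1 to compound 2 (beyond the scatter).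

Compound 4, `Cc1ccc(N2C(=O)C(c3ccccc3)CC(c3ccccc3)C2=O)cc1`, differs from compound 3 in one place: 4-methylphenyl in place of 3-chlorophenyl on an amide-type nitrogen in a ring. Among the compounds with values here, no measured step exchanges one six-membered aromatic ring of carbon only for another on that nitrogen; the steps that bear on the position are the two ending at compound 3, both large and both downward. Compound 4 keeps a six-membered aromatic ring of carbon only directly on the same nitrogen, so it is expected to stay near compound 3 rather than return to the level of compound 1 or compound 2. The expected step is a number 5.8 percentage points higher from compound 3 to compound 4 (within the scatter), none beyond the scatter. The estimate for compound 4 in this assay is 38%, with a range from 20% to 58%.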

Compound 4, a percentage reported as inhibition, in the whole organism at one dose (the size of the read-out at that dose, not a potency): 43.3%
For compound 4 the middle estimate is 5.3 percentage points below the measured one; measured number inside the range.
By their numbers in this assay, from the lowest: compound 3; then compound 4; then compound 1; then compound 2.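

In this assay, exchanging one six-membered aromatic ring of carbon only for another on the amide-type nitrogen still moves the number, with a number 11.1 percentage points higher from compound 3 to compound 4 (beyond the scatter), so the nature of that ring matters and not only its presence. The ring-bearing compounds nevertheless stay low against the other two groups, with a number 21.2 percentage points lower from compound 1 to compound 4 (beyond the scatter) and a number 32.7 percentage points lower from compound 2 to compound 4 (beyond the scatter), and this holds for 4-methylphenyl as it did for 3-chlorophenyl. Nothing measured here explains any of these differences.

The compounds shown leave open whether the step follows the methyl group, the loss of chlorine or the place of each on the ring: 4-methylphenyl and 3-chlorophenyl differ in all of these, and a plain phenyl, 3-methylphenyl or 4-chlorophenyl on that nitrogen would separate them. Also open, as far as these compounds go, is how a longer chain such as phenethyl would stand against benzyl.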